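Adding methoxy to compound 2: working notes

The compounds below may be only part of what the source reports. "The series", "measured", "known", "first", "only" and "open" are said of these compounds alone.

Measured in a functional assay on HepG2 cells (Homo sapiens) for inhibition, read by MTT assay, with a stated time of 48 h (a lower number here means a stronger inhibitor of growth, a higher number a weaker inhibitor of growth), as follows:
- compound 1 `COc1ccc2c(c1)c(C1CC(c3cc(OC)c(OC)c(OC)c3)=NN1C(=O)c1ccc(OC)nc1)cn2C` gives > 10000 nM (a limit)
- compound 2 `COc1cccc(C2=NN(C(=O)c3cccnc3)C(c3cn(C)c4ccc(OC)cc34)C2)c1` gives 910 nM (a number)

Among the compounds with values here, compound 2 holds the only actual number in this assay so far, and the other result is a limit. Compound 3 `COc1cccc(C2=NN(C(=O)c3ccc(OC)nc3)C(c3cn(C)c4ccc(OC)cc34)C2)c1` has methoxy in place of hydrogen on an aromatic carbon of compound 2 (methoxy in place of hydrogen on an aromatic carbon) and so carries a 6-methoxypyridin-3-yl group. Compound 1 also carries this group and shows > 10000 nM (a limit), but it differs elsewhere too. Within the data shown here, no measured pair isolates the change, so only a small weakening, within the scatter, is expected. The estimated change is a 1.5-fold higher number from compound 2 to compound 3 (0.19 log units; within the scatter) (expected, and uncertain). For compound 3 the expected value is 1400 nM (estimated range 300 nM to 7000 nM).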

Compound 3, concentration for 50% growth inhibition: 190 nM
For compound 3 the middle estimate is 7.4-fold (0.87 log units) above the measured one; the whole stated range lies above it.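

In this assay, methoxy on the aromatic carbon next to the ring nitrogen of the pyridin-3-yl group gives a 4.8-fold lower number from compound 2 to compound 3 (0.68 log units; beyond the scatter), so this position responds to substitution. With the 6-methoxypyridin-3-yl group kept, 3-methoxyphenyl in place of 3,4,5-trimethoxyphenyl gives an at least 52-fold lower number from compound 1 to compound 3 (1.72 log units; beyond the scatter), so compound 1 says nothing against this methoxy. That step rests on a limit for compound 1, not on a number: the limit of > 10000 nM in this assay, at which 1 of the 3 values shown sits.

Open, as far as these compounds go, is whether ethoxy or an amine at this carbon would give a similar step. Also open, from the compounds shown here alone, is whether methoxy here would matter alongside 3,4,5-trimethoxyphenyl.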